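Shortening a Linker on a Hexokinase-2 Probe

The source may hold more compounds than are shown below. What is called first, only, known or untested is meant among the compounds shown, and "the series" means these compounds.

Measured so far:
compound 1 `Nc1ncnc2c1nc(NCCCCNC(=O)CI)n2[C@@H]1O[C@H](COP(=O)(O)OP(=O)(O)OP(=O)(O)O)[C@@H](O)[C@H]1O` — 0%
compound 2 `O=C(CI)NCCCCCC(=O)NCCCCNc1ncnc2c1ncn2[C@@H]1O[C@H](COP(=O)(O)OP(=O)(O)OP(=O)(O)O)[C@@H](O)[C@H]1O` — 0%

In an assay on isolated protein for inhibition of hexokinase-2 (Rattus norvegicus), with a stated time of 6 h, tested at 10 mM (a higher number here means more inhibition at the concentration tested (going by the name of the read-out), a lower number less inhibition), compound 1 gives 0%. Compound 2, which carries a longer chain built from two amide links, gives 0% in this assay. The two values sit level with each other, and both show that neither compound blocks the enzyme to a detectable degree under these conditions.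

Compound 3 `Nc1ncnc2c1nc(NCCNC(=O)CI)n2[C@@H]1O[C@H](COP(=O)(O)OP(=O)(O)OP(=O)(O)O)[C@@H](O)[C@H]1O` has not yet been tested. It differs from compound 1 only in the chain that carries the iodoacetamide end: ((iodomethyl)carbonyl)amino in place of 2-(((iodomethyl)carbonyl)amino)ethyl on a saturated chain carbon, two bonds along the chain from a nitrogen on an aromatic ring. The reactive group is kept, but it now sits closer to the shared core.

For the measured compounds named here, no step between two measured compounds exists here from which the effect of such a shortening could be read. Going by the values given here, with compound 1 at 0% and compound 2 at 0%, the only guidance is that two chain lengths already tried gave no inhibition. The expected step of no change at the digits printed from compound 1 to compound 3 (within the scatter) from compound 1 to compound 3 in this assay is therefore none beyond the scatter. Compound 3 is expected to give about 0%, most likely between 0% and 10%.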

Compound 3, a percentage reported as inhibition, at one concentration (the size of the read-out at that concentration, not a potency): 0%
Compound 3: the middle estimate sits on the measured number at the digits printed; measured number inside the range.
By their numbers in this assay, from the lowest: compounds 1, 2 and 3 (each within the scatter of the next).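

For the compounds shown here, for the first time, a single change at this position can be read: ((iodomethyl)carbonyl)amino in place of 2-(((iodomethyl)carbonyl)amino)ethyl on a saturated chain carbon, two bonds along the chain from a nitrogen on an aromatic ring, gives no change at the digits printed from compound 1 to compound 3 (within the scatter) in this assay. Bringing the iodoacetamide end closer to the shared core therefore does not bring out inhibition at the concentration tested, and with compound 1 already at 0%, this read-out could only have shown a gain, which this step does not show. No separate measurement bears on why the read-out stays the same.

The compounds shown leave open whether any chain length at this position matters, as a read-out with no inhibition at either end of the step cannot separate a better fit from a worse one. They also leave open whether a different reactive end on the same chain, such as a bromoacetamide or an acrylamide, would give a measurable value in this assay.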